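Swapping a methyl for a hydroxyethylsulfanyl chain

The compounds below may be only part of what the source reports. "The series", "measured", "known", "first", "only" and "open" are said of these compounds alone.

Measured compounds: compound 1 `CCCc1nc(NS(=O)(=O)c2ccc(C(C)(C)C)cc2)c(-c2ccc(C)cc2)c(OCCOc2ncc(Br)cn2)n1` with 1.6 nM and compound 2 `COc1ccccc1Oc1c(NS(=O)(=O)c2ccc(C(C)(C)C)cc2)nc(C)nc1OCCOc1ncc(Br)cn1` with 2.7 nM in an assay on cell membranes for binding affinity to Endothelin-1 receptor (Sus scrofa); a higher number here means a weaker inhibitor, a lower number a stronger inhibitor.

Compound 2 and compound 1 differ only within the usual scatter of this assay, so neither can be set apart from the other. Compound 3 `COc1ccccc1Oc1c(NS(=O)(=O)c2ccc(C(C)(C)C)cc2)nc(SCCO)nc1OCCOc1ncc(Br)cn1` takes compound 2 as its starting point; the change is (2-hydroxyethyl)sulfanyl in place of methyl on an aromatic carbon. Among the compounds with values here, no measured pair shows the effect of this change, so its size is open. Compound 3 is expected to stay close to compound 2, with a 1.1-fold lower number from compound 2 to compound 3 (0.03 log units; within the scatter) taken as no step beyond the scatter, giving an estimated 2.5 nM within 0.7 nM to 9 nM.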

Compound 3, half-maximal inhibitory concentration: 0.15 nM
Compound 3: middle estimate off by 17-fold (1.22 log units), on the high side, outside the stated range (below it).
By their numbers in this assay, from the lowest: compound 3; then compounds 1 and 2 (each within the scatter of the next).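

On an aromatic carbon between two ring nitrogen atoms, (2-hydroxyethyl)sulfanyl in place of methyl gives an 18-fold lower number from compound 2 to compound 3 (1.26 log units; beyond the scatter) in this assay. Within the data shown here, this is the first step between measured compounds that differ in one place, and it shows that the group at this position can shift the number well beyond the scatter. No measurement given here bears on the reason for this step.

On these data alone, it remains open whether the sulfur, the two-carbon chain or the terminal hydroxyl carries the step. As far as these compounds go, how a methylsulfanyl group, a longer hydroxyalkyl chain or an amine would read at this position is also open.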